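This account rests on a few compounds, and the source may have more. Where it says the series, first, only, none or still open, it means among the compounds named here.

Measured so far:
Compound 1 `O=C(N/N=C/c1c[nH]c2ccc(Br)cc12)C(=O)c1c[nH]c2ccccc12`: 6600 nM
Compound 2 `O=C(N/N=C/c1c[nH]c2ccccc12)C(=O)c1cn(Cc2ccc(Cl)cc2)c2ccccc12`: 150 nM

In a functional assay on HCT-116 cells (Homo sapiens) for cytotoxicity, read by MTT assay, with a stated time of 48 h (on this read-out lower numbers stand for stronger inhibition and higher numbers for weaker inhibition), compound 2 holds the lower of the two numbers. Compound 1 gives 6600 nM, while compound 2 gives 150 nM, a gap well beyond the scatter of repeated measurements. The next compound to be tested in this assay is compound 3 `COc1ccc2[nH]cc(/C=N/NC(=O)C(=O)c3cn(Cc4ccc(Cl)cc4)c4ccccc34)c2c1`, which departs from compound 2 in one place only: methoxy in place of hydrogen on an aromatic carbon. In words, this is methoxy in place of hydrogen on an aromatic carbon, and the same difference can be read as 1H-indol-3-yl to 5-methoxy-1H-indol-3-yl.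

Within the data shown here, no two measured compounds differ in one place, so the data contain no direct precedent for this change. Compound 1 and compound 2 differ in more than one place, and their gap cannot be assigned to any single one. With nothing to indicate a direction, the working expectation stays close to compound 2 at 150 nM. The expected change is a 1.1-fold lower number from compound 2 to compound 3 (0.03 log units; within the scatter), which would be no step beyond the scatter. For compound 3 the estimated value is 140 nM, with an expected range from 40 nM to 550 nM.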

Compound 3, half-maximal inhibitory concentration: 4200 nM
The estimate for compound 3 lay 30-fold (1.48 log units) below the measured number; the whole stated range lies below it.
By their numbers in this assay, from the lowest: compound 2; then compounds 3 and 1 (each within the scatter of the next).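

In this assay, among these compounds, methoxy in place of hydrogen on an aromatic carbon gives a 28-fold higher number from compound 2 to compound 3 (1.45 log units; beyond the scatter) and so provides the first reading of a single change. Compound 1 and compound 2 differ in more than one place and could not isolate any one position, whereas this pair shows that the change from 1H-indol-3-yl to 5-methoxy-1H-indol-3-yl, at a carbon meta to a fused ring and para to a fused ring, can by itself carry a large loss on this read-out. No measurement at hand accounts for the size of this step.

This one pair does not settle whether the step belongs to methoxy in particular or would follow other groups at the same carbon, and a fluorine atom, a methyl or a hydroxyl there would help to separate these readings. It also leaves open whether the same change would give a step of similar size in a compound carrying something other than the 4-chlorobenzyl group of compound 2, such as a plain methyl on that indole nitrogen.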